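Nitro for methoxy on compound 2

The source may hold more compounds than are shown below. What is called first, only, known or untested is meant among the compounds shown, and "the series" means these compounds.

In a functional assay on HeLa cells (Homo sapiens) for inhibition, read by CCK-8 assay, with a stated time of 48 h (a lower number here means a stronger inhibitor, a higher number a weaker inhibitor), compound 1 `O=S(=O)(NCCNC(=S)Nc1cc(C(F)(F)F)cc(C(F)(F)F)c1)c1ccc(-c2ccccc2OCc2cccc(O)c2)s1` gives 14900 nM. Compound 2 `COc1ccc(NC(=O)NCCNS(=O)(=O)c2sccc2-c2ccc(C)cc2Oc2ccc(O)c(O)c2)cc1` reads > 20000 nM, which is a limit of the assay and not a number. Compound 3 `Cc1ccc(-c2ccsc2S(=O)(=O)NCCNC(=O)Nc2ccc([N+](=O)[O-])cc2)c(Oc2ccc(O)c(O)c2)c1` carries nitro in place of methoxy on an aromatic carbon, para to a large group: nitro in place of methoxy on an aromatic carbon. For the measured compounds named here, no measured pair of compounds shows what such a change does, so no step beyond the usual scatter is expected in this assay, and no direction is favoured. The expected change is a number no higher from compound 2 to compound 3 (the limit leaves the size open). The estimate for compound 3 is 20000 nM, with an expected range from 9000 nM to 45000 nM.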

Compound 3, half-maximal inhibitory concentration: > 20000 nM
Compound 3 ended at the assay's limit; the forecaster's own chance of this, stated with the estimate: 50%; the middle value sits exactly at the limit.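

Compound 2 and compound 3 both stand at a limit of the assay and not at a number, and no step can be read between them. On these data alone, what nitro in place of methoxy does in this assay stays open.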